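Swapping benzyl for oxan-2-yl on compound 2

The source may hold more compounds than are shown below. What is called first, only, known or untested is meant among the compounds shown, and "the series" means these compounds.

Compound 1 `CSc1cc(/C=C/c2ccc(OC3CCCCO3)cc2)nc(N)n1`: 122000 nM
Compound 2 `COc1ccc(Nc2cc(/C=C/c3ccc(OCc4ccccc4)cc3)nc(N)n2)cc1`: 57800 nM

Both numbers come from an ADME assay on Vero cells (Chlorocebus sabaeus) for cytotoxicity, read by MTT assay, with a stated time of 72 h; a higher number here means that more compound is tolerated, a lower number that less compound is tolerated. Compound 2 stands lowest of the two at 57800 nM, and its gap to compound 1 lies just beyond the usual scatter. The next molecule, compound 3 `COc1ccc(Nc2cc(/C=C/c3ccc(OC4CCCCO4)cc3)nc(N)n2)cc1`, keeps the rest of compound 2 and makes one change: oxan-2-yl in place of benzyl on an oxygen on an aromatic ring.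

Going by the values given here, no two measured compounds differ in one place only, so the data show no direct precedent for this swap. The only hint is indirect: compound 1 also carries oxan-2-yl and gives 122000 nM, though it differs from compound 3 elsewhere as well. A small rise is therefore expected, and a 1.5-fold higher number from compound 2 to compound 3 (0.17 log units; within the scatter) is estimated to stay close to the scatter. Compound 3 is estimated at 85000 nM, with an expected range of 35000 nM to 180000 nM.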

Compound 3, half-maximal cytotoxic concentration: 345000 nM
The estimate for compound 3 lay 4.1-fold (0.61 log units) below the measured number; the measured number lies above the stated range.
By their numbers in this assay, from the lowest: compound 2; then compound 1; then compound 3.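

In this assay, oxan-2-yl in place of benzyl on an oxygen on an aromatic ring gives a 6.0-fold higher number from compound 2 to compound 3 (0.78 log units; beyond the scatter), which shows that the group on this oxygen can shift the tolerated concentration beyond the scatter. With oxan-2-yl kept, (4-methoxyphenyl)amino in place of methylsulfanyl on an aromatic carbon gives a 2.8-fold higher number from compound 1 to compound 3 (0.45 log units; beyond the scatter), so a change at this second place also raises the number. Nothing measured here explains either rise.

On these data alone, it remains open whether this rise is specific to oxan-2-yl or would also appear with a hydroxyl, a methoxy or a longer alkyl chain on the same oxygen. As far as these compounds go, it is also open whether swapping benzyl for oxan-2-yl would have a similar effect with methylsulfanyl in place of (4-methoxyphenyl)amino.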